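This account rests on a few compounds, and the source may have more. Where it says the series, first, only, none or still open, it means among the compounds named here.

In a functional assay on SEM cells (Homo sapiens) for cytotoxicity, with a stated time of 72 h (on this read-out higher numbers stand for an effect only at larger amounts of compound and lower numbers for an effect already at smaller amounts), compound 1 `CC(C)=CCC[C@@](C)(/C=C/c1ccccc1)/C=C/c1ccc(O)cc1` gives > 36600 nM, which is a limit of the assay and not a number. Compound 2 `CC(C)=CCC[C@](C)(/C=C/c1ccc(O)cc1)/C=C/c1ccc(C#N)cc1` gives > 36600 nM, which is also a limit. Among the measured compounds shown here, compound 2 therefore has no exact position on this scale, and the only evidence so far is the limit of > 36600 nM in this assay, at which 2 of the 2 values shown sit. For the measured compounds named here, the one measured step, a step that the two limits leave unreadable from compound 1 to compound 2, puts cyano in place of hydrogen on an aromatic carbon, and its size cannot be read.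

Compound 3 `CC(C)=CCC[C@](C)(/C=C/c1ccc(O)cc1)/C=C/c1cccc(Cl)c1` has not yet been measured. Its change from compound 2 is 3-chlorophenyl in place of 4-cyanophenyl on a double-bonded chain carbon bound to a double-bonded chain carbon. No readable step exists to carry over to this change, so no firm size or direction can be drawn from the data. In this assay, the most likely outcome is another limit, although a modest shift toward effect at smaller amounts remains possible. The expected change is an at least 1.2-fold lower number from compound 2 to compound 3 (0.08 log units; that floor lies within the scatter), an estimate that carries little certainty. For compound 3, the estimated value is 30000 nM, with an expected range from 10000 nM to 60000 nM.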

Compound 3, half-maximal effective concentration: > 36600 nM
Compound 3: only a limit was reported; the forecaster's own chance of this, stated with the estimate: 70%; middle value at least 1.2-fold (0.08 log units) away from the limit.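

In this assay compound 3 gives > 36600 nM, which is a limit of the assay and not a number. No step among compound 1, compound 2 and compound 3 can therefore be read: the limit of > 36600 nM in this assay, at which 3 of the 3 values shown sit.

The compounds shown leave open at what amount each of the three takes effect, and whether 4-cyanophenyl or 3-chlorophenyl changes that amount.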